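A few compounds are considered here, and "the series" means these few. Any claim that something is new, unique, unknown or untested is made for them only; others in the source may bear on it.

In a functional assay on Huh-7 cells (Homo sapiens) for inhibition, read by CCK-8 assay, with a stated time of 72 h (on this read-out lower numbers stand for stronger inhibition and higher numbers for weaker inhibition), compound 1 (`O=C(/C=C/c1cccnc1)NCCCCCCCc1ccc(S(=O)(=O)Nc2ccccc2)cc1`) gives 1230 nM and compound 2 (`Cc1cccc(NS(=O)(=O)c2cccc(CCCCCCNC(=O)/C=C/c3cccnc3)c2)c1`) gives 13.2 nM, the lower of the two numbers and beyond the scatter. Compound 3 (`O=C(/C=C/c1cccnc1)NCCCCCCc1cccc(S(=O)(=O)Nc2ccc(F)c(Cl)c2)c1`) carries 3-chloro-4-fluorophenyl in place of 3-methylphenyl on a sulfonamide nitrogen. Among the compounds with values here, no measured pair isolates a change at this place, so the expectation rests on little. The expected step of a 1.2-fold higher number from compound 2 to compound 3 (0.08 log units; within the scatter) is small, slightly toward weaker inhibition and within the scatter. For compound 3 the estimate is 16 nM, with an expected range of 4 nM to 70 nM.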

Compound 3, half-maximal inhibitory concentration: 39.4 nM
Compound 3: middle estimate off by 2.5-fold (0.39 log units), on the low side; the range from low to high includes it.
By their numbers in this assay, from the lowest: compound 2; then compound 3; then compound 1.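

In this assay, 3-chloro-4-fluorophenyl in place of 3-methylphenyl on a sulfonamide nitrogen gives a 3.0-fold higher number from compound 2 to compound 3 (0.47 log units; beyond the scatter), the only pair shown that isolates a change at this place. The position is therefore not silent: exchanging one substituted phenyl for another moves the number beyond the scatter, though modestly. Nothing measured here gives a reason for this step.

The chlorine and fluorine enter together as the methyl leaves, so their separate contributions remain unresolved. Also open, from the compounds shown here alone, is how 3-chlorophenyl, 4-fluorophenyl or a pyridine ring would read at this nitrogen.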